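Naphthalen-2-yl for nitrophenyl on the dichloro core

The compounds below may be only part of what the source reports. "The series", "measured", "known", "first", "only" and "open" are said of these compounds alone.

Compound 1 `C=C(CC)C(=O)c1ccc(OCc2nc(-c3ccc([N+](=O)[O-])cc3)cs2)cc1Cl`: 800 nM
Compound 2 `C=C(CC)C(=O)c1ccc(OCc2nc(-c3ccc4ccccc4c3)cs2)cc1Cl`: 900 nM
Compound 3 `C=C(CC)C(=O)c1ccc(OCc2nc(-c3ccc([N+](=O)[O-])cc3)cs2)c(Cl)c1Cl`: 1000 nM

In a functional assay on HL-60 cells (Homo sapiens) for inhibition, read by trypan blue exclusion, with a stated time of 72 h (a higher number here means a weaker inhibitor of growth, a lower number a stronger inhibitor of growth), compound 3 gives 1000 nM, the highest of the three numbers, yet compound 2 sits within the scatter of it and the step of a 1.3-fold higher number from compound 1 to compound 3 (0.10 log units; within the scatter) is likewise within the scatter, so no order among the three can be read. Compound 4 `C=C(CC)C(=O)c1ccc(OCc2nc(-c3ccc4ccccc4c3)cs2)c(Cl)c1Cl` differs from compound 3 in one place: naphthalen-2-yl in place of 4-nitrophenyl on an aromatic carbon. The same exchange has been measured once on the monochloro core, where a 1.1-fold higher number from compound 1 to compound 2 (0.05 log units; within the scatter), a step within the scatter. Compound 4 is therefore expected to stay within the scatter of compound 3, a 1.1-fold higher number from compound 3 to compound 4 (0.04 log units; within the scatter). The estimate for compound 4 in this assay is 1100 nM, with a range from 500 nM to 2500 nM.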

Compound 4, concentration for 50% growth inhibition: 3600 nM
The estimate for compound 4 lay 3.3-fold (0.51 log units) below the measured number, outside the stated range (above it).
By their numbers in this assay, from the lowest: compounds 1, 2 and 3 (each within the scatter of the next); then compound 4.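

In this assay, naphthalen-2-yl in place of 4-nitrophenyl gives a 3.6-fold higher number from compound 3 to compound 4 (0.56 log units; beyond the scatter) on the core of compound 3, so the exchange is not neutral on every core: the same change on two cores in this assay, a 1.1-fold higher number (0.05 log units; within the scatter) from compound 1 to compound 2 and a 3.6-fold higher number (0.56 log units; beyond the scatter) from compound 3 to compound 4, 3.2-fold (0.51 log units) apart, beyond the scatter of two such steps

Chloro in place of hydrogen likewise gives a 4.0-fold higher number from compound 2 to compound 4 (0.60 log units; beyond the scatter) when naphthalen-2-yl is present, and its size depends on the group at this position: the same change on two cores in this assay, a 1.3-fold higher number (0.10 log units; within the scatter) from compound 1 to compound 3 and a 4.0-fold higher number (0.60 log units; beyond the scatter) from compound 2 to compound 4, 3.2-fold (0.51 log units) apart, beyond the scatter of two such steps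

The compounds shown leave open whether an unsubstituted phenyl, a 4-aminophenyl or a 4-carboxyphenyl at this ring carbon would stay with compound 3 or fall with compound 4 on the core of compound 3.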